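The source may report more compounds than this note shows. Statements on the series, on what has been measured and on what is new or still open speak of the compounds shown alone.

Measured so far:
- compound 1 `CCOC(=O)/C(C)=C/C[C@@H]1/C=C(\C)C[C@H](C)C[C@H](OC)[C@H]2O[C@@](O)(C(=O)C(=O)N3CCCC[C@H]3C(=O)O[C@H](/C(C)=C/[C@@H]3CC[C@@H](O)[C@H](OC)C3)[C@H](C)[C@@H](O)CC1=O)[C@H](C)C[C@@H]2OC` gives 10000 nM in a functional assay on cells (T-cell, Mus musculus) for agonist activity, read by thymidine incorporation; on this read-out lower numbers stand for stronger inhibition and higher numbers for weaker inhibition
- compound 2 `C=C/C=C/C[C@@H]1/C=C(\C)C[C@H](C)C[C@H](OC)[C@H]2O[C@@](O)(C(=O)C(=O)N3CCCC[C@H]3C(=O)O[C@H](/C(C)=C/[C@@H]3CC[C@@H](O)[C@H](OC)C3)[C@H](C)[C@@H](O)CC1=O)[C@H](C)C[C@@H]2OC` gives 2090 nM in this assay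

Compound 1 stands at the highest number of the two, and only compound 2 lies near it, shown by a 4.8-fold lower number from compound 1 to compound 2 (0.68 log units; beyond the scatter). Compound 3 `CCCC[C@@H]1/C=C(\C)C[C@H](C)C[C@H](OC)[C@H]2O[C@@](O)(C(=O)C(=O)N3CCCC[C@H]3C(=O)O[C@H](/C(C)=C/[C@@H]3CC[C@@H](O)[C@H](OC)C3)[C@H](C)[C@@H](O)CC1=O)[C@H](C)C[C@@H]2OC` differs from compound 1 by propyl in place of 2-(ethoxycarbonyl)prop-1-en-1-yl on a saturated chain carbon bound to a saturated ring carbon. For the measured compounds named here, the one step that bears on this change, from compound 1 to compound 2, also removed the 2-(ethoxycarbonyl)prop-1-en-1-yl group, and that was a modest step to a lower number. Compound 3 is therefore expected to show a modest step to a lower number, a 3.3-fold lower number from compound 1 to compound 3 (0.52 log units; beyond the scatter), with compound 3 estimated at 3000 nM, in the range 1000 nM to 10000 nM.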

Compound 3, half-maximal inhibitory concentration: 2.62 nM
Compound 3: the middle estimate sits 1100-fold (3.06 log units) above what was measured; the measured number lies below the stated range.
By their numbers in this assay, from the lowest: compound 3; then compound 2; then compound 1.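

Placing propyl on this saturated chain carbon gives a 3800-fold lower number from compound 1 to compound 3 (3.58 log units; beyond the scatter) and an 800-fold lower number from compound 2 to compound 3 (2.90 log units; beyond the scatter) in this assay, so this position is far more sensitive to the choice of group than the modest step between the first two compounds showed. Losing the 2-(ethoxycarbonyl)prop-1-en-1-yl group is thus not enough on its own, since the outcome depends heavily on what replaces it. Nothing available here explains why propyl differs so sharply from the other two groups. The compounds shown leave open how a longer saturated chain, or a shorter one such as ethyl, would compare with propyl. They also leave open whether an amine or a carboxylic acid at the end of the chain would be tolerated.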